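Pyrazole to Triazole: An Untested Substitution

A few compounds are considered here, and "the series" means these few. Any claim that something is new, unique, unknown or untested is made for them only; others in the source may bear on it.

Three ureas built on one shared core have been measured in an assay on microsomes from intestine for inhibition of acyl-CoA:cholesterol acyltransferase (Oryctolagus cuniculus); on this read-out higher numbers stand for weaker inhibition and lower numbers for stronger inhibition. Compound 1 `Cc1cc(C)c(NC(=O)N(Cc2c[nH]c(-c3ccccc3)n2)C2CCCCCC2)c(C)c1` gives 750 nM. Compound 2 `Cc1cc(C)c(NC(=O)N(Cc2cccc(-c3cc[nH]n3)c2)C2CCCC2)c(C)c1` gives 22 nM. Compound 3 `Cc1cc(C)c(NC(=O)N(Cc2ccc(-c3cc[nH]n3)cc2)C2CCCCCC2)c(C)c1` gives 52 nM, which stands as the second highest of the three numbers; its nearest neighbour is compound 2, and that gap lies beyond the scatter, as does the much larger gap to compound 1. No two of these compounds differ in a single place, so no one-point step can be read from the measured set.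

Compound 4 `Cc1cc(C)c(NC(=O)N(Cc2ccc(-n3nccn3)cc2)C2CCCCCC2)c(C)c1` has not yet been tested. It differs from compound 3 in one place: 2H-1,2,3-triazol-2-yl in place of 1H-pyrazol-3-yl on an aromatic carbon. The hydrogen-bond donor counted for the pyrazole is thereby lost, and the entering ring carries three acceptors. Among the compounds with values here, nothing among the measured compounds shows what this exchange does in this assay, so the expectation rests on the change alone. The step that this estimate implies, a 2.9-fold higher number from compound 3 to compound 4 (0.46 log units; beyond the scatter), is expected to be a modest rise in the number, toward weaker inhibition, only a little beyond the scatter. Compound 4 is accordingly estimated at 150 nM, with a range from 40 nM to 600 nM.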

Compound 4, half-maximal inhibitory concentration: 130 nM
Compound 4: middle estimate off by 1.2-fold (0.06 log units), on the high side, within the range that was stated.
By their numbers in this assay, from the lowest: compound 2; then compound 3; then compound 4; then compound 1.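

In this assay, within the data shown here, the exchange of 1H-pyrazol-3-yl for 2H-1,2,3-triazol-2-yl on an aromatic carbon, para to a large group, gives the first one-place comparison in this set: a 2.5-fold higher number from compound 3 to compound 4 (0.40 log units; beyond the scatter), a modest move toward weaker inhibition. Compound 4 still gives 130 nM without the hydrogen-bond donor counted for the pyrazole, so at this position a ring with 0 hydrogen-bond donors and 3 hydrogen-bond acceptors remains compatible with inhibition, although at a higher number than the pyrazole gives. Nothing measured here accounts for the rise or assigns it to any one difference between the two rings.

Because this single exchange changes the donor and acceptor counts together, the compounds shown do not separate the contribution of either, and a pyrazole carrying a methyl group on a ring nitrogen, or a 1H-imidazol-1-yl ring, could test them further. Going by these compounds, it also remains open whether a step of this size would recur with a cyclopentyl group in place of the larger ring, or with the five-membered ring placed elsewhere on the six-membered aromatic ring.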